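Ring-to-Chain Swap on the Amine of Compound 2

This account rests on a few compounds, and the source may have more. Where it says the series, first, only, none or still open, it means among the compounds named here.

Three compounds have been measured in an assay on IMR-32 cells for inhibition of melanin-concentrating hormone receptor 1 (Homo sapiens); on this read-out higher numbers stand for weaker inhibition and lower numbers for stronger inhibition:

compound 1 `CC(C)Nc1ncc(Cl)cc1C(=O)NC1CCN(Cc2ccc3c(c2)CCO3)CC1`, giving 70 nM
compound 2 `O=C(NC1CCN(Cc2ccc(Cl)cc2)CC1)c1cc(Cl)cnc1NC1CCC1`, giving 1980 nM
compound 3 `COc1ccc(CN2CCC(NC(=O)c3cc(Cl)cnc3NCC(C)C)CC2)cc1F`, giving 160 nM

Compound 2 stands at the highest number of the three. Its nearest neighbour is compound 3, whose number is lower by a margin that lies beyond the usual scatter, and compound 1 lies further still below it. Compound 2 is therefore the weakest inhibitor among the measured set.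

The next compound, compound 4 `O=C(NC1CCN(Cc2ccc(Cl)cc2)CC1)c1cc(Cl)cnc1NCC1CC1`, keeps everything in compound 2 except one group: cyclopropylmethyl in place of cyclobutyl on a nitrogen on an aromatic ring. Going by the values given here, no pair of measured compounds differs in exactly this way, so the size of the step cannot be read from the data. Compounds 1 and 3 carry open-chain groups on that nitrogen and give lower numbers than compound 2, but each also carries a different benzyl part, so their values show only where they stand, not what this single change does.

Compound 4 is expected to move modestly downward, by a 2.2-fold lower number from compound 2 to compound 4 (0.34 log units; beyond the scatter), because compound 2 sits at 1980 nM and leaves room for improvement. Compound 4 is estimated at 900 nM, with a range from 300 nM to 3000 nM.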

Compound 4, half-maximal inhibitory concentration: 410 nM
Beside the measured number, compound 4's estimate is 2.2-fold (0.34 log units) above it, and the stated range covers the measured number.
By their numbers in this assay, from the lowest: compound 1; then compound 3; then compound 4; then compound 2.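

In this assay, replacing cyclobutyl with cyclopropylmethyl on a nitrogen on an aromatic ring gives a 4.8-fold lower number from compound 2 to compound 4 (0.68 log units; beyond the scatter), a modest step that lies beyond the usual scatter. Going by these compounds alone, this is the first change in the set made at this position with everything else held constant, so it shows that this group alone can shift the read-out, which the differing benzyl parts of compound 1 and compound 3 could not reveal. The two groups have the same atoms joined differently, each with a ring of carbon only, so the atom content does not settle the number here, and nothing measured explains why the rearrangement moves it.

On these data alone, it remains open how an open-chain group on this nitrogen, such as the isobutyl of compound 3, would compare when carried with the chlorobenzyl part shared by compound 2 and compound 4. Also open, as far as these compounds go, are whether a cyclopentyl ring or a longer chain such as n-butyl at the same place would lower the number further, and whether this step would keep its size with the benzyl part of compound 1 or compound 3.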